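The compounds below may be only part of what the source reports. "The series", "measured", "known", "first", "only" and "open" are said of these compounds alone.

Compound 3, with the structure `COc1ccc(/C=C2\CCC/C(=C\c3ccccc3Cl)C2=O)cc1OC`, is one of three measured members of a small set of bis-benzylidene ketones. In a functional assay on A549 cells (Homo sapiens) for cytotoxicity, read by MTT assay, with a stated time of 72 h (a lower number here means a stronger inhibitor, a higher number a weaker inhibitor), compound 3 gives only a limit, > 20000 nM, not a number. Compound 1, `COc1cccc(/C=C2\CCC/C(=C\c3cccc(O)c3)C2=O)c1OC`, likewise reaches only a limit in this assay, > 20000 nM. Compound 2, `COc1cccc(/C=C2\CCC/C(=C\c3cccc(Cl)c3Cl)C2=O)c1OC`, also stops at a limit in this assay, > 20000 nM. The one single-point step among these, a step that the two limits leave unreadable from compound 1 to compound 2, cannot be sized, because all three values sit at the same boundary, as the limit of > 20000 nM in this assay, at which 3 of the 3 values shown sit, records.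

Compound 4, `COc1cc(/C=C2\CCC/C(=C\c3ccc(OC)c(OC)c3)C2=O)ccc1O`, differs from compound 3 by 4-hydroxy-3-methoxyphenyl in place of 2-chlorophenyl on a double-bonded chain carbon bound to a double-bonded ring carbon. Within the data shown here, no measured step shares this exact change, so the comparison rests on the fact that every measured compound, whatever aryl group it carries, fails to reach the limit in this assay. Among the measured compounds shown here, nothing among the measured steps points to a direction beyond the scatter.

The author therefore expects compound 4 to show no step beyond the scatter in this assay, with a step that the limit leaves unreadable from compound 3 to compound 4 as the expected step, and most likely another limit. The estimate for compound 4 in this assay is 25000 nM, with a range from 8000 nM to 80000 nM.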

Compound 4, half-maximal inhibitory concentration: 10300 nM
Compound 4: the middle estimate sits 2.4-fold (0.39 log units) above what was measured, within the range that was stated.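

Among these compounds, at this position, on a double-bonded chain carbon bound to a double-bonded ring carbon, 4-hydroxy-3-methoxyphenyl in place of 2-chlorophenyl yields the first true number in this set in this assay, where compound 4 gives 10300 nM. The step is an at least 1.9-fold lower number from compound 3 to compound 4 (0.28 log units; that floor lies within the scatter), so the result gives the change a direction but only a floor for its size, and that floor alone does not establish a change beyond the scatter. Among the compounds shown here, the earlier compounds could show only that different aryl groups left the readout at one boundary, whereas compound 4 now stands apart from it, and the remaining compounds stay there: the limit of > 20000 nM in this assay, at which 3 of the 4 values shown sit.

With the rest of compound 3 kept, the compounds shown do not separate the part played by the hydroxy group from that of the methoxy group within 4-hydroxy-3-methoxyphenyl. They also leave open how an amine, a carboxylic acid or a longer chain at this same place would read in this assay, and whether any of these would move the value further from the limit.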